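The source may hold more compounds than are shown below. What is called first, only, known or untested is meant among the compounds shown, and "the series" means these compounds.

Three compounds share one core and differ only in the group on one aromatic carbon. Compound 1 `CCCCCCCCCCc1ccc(-c2noc(CCCNC)n2)cc1` gives 45% in an assay on HeLa cells for inhibition of sphingosine-1-phosphate transporter SPNS2 (Mus musculus), read by LC-MS, tested at 2 uM; on this read-out higher numbers stand for more inhibition at the one concentration tested (going by the name of the read-out) and lower numbers for less inhibition. Compound 2 `CCCCCCCCCCc1ccc(-c2noc(CCCN(C)C)n2)cc1` gives 8%, and compound 3 `CCCCCCCCCCc1ccc(-c2noc([C@@H]3CCC[C@@H](N)C3)n2)cc1` gives 13%, the second highest of the three numbers, within the scatter of compound 2 and beyond it below compound 1. Compound 4 `CCCCCCCCCCc1ccc(-c2noc(CC[C@@H](N)C(=O)O)n2)cc1` changes that same position: 3-amino-3-carboxypropyl in place of 3-aminocyclohexyl on an aromatic carbon. Two earlier steps bear on this position, a large drop from a number 32 percentage points lower from compound 1 to compound 3 (beyond the scatter) and a change within the scatter from a number 5 percentage points higher from compound 2 to compound 3 (within the scatter), so swaps here can matter much or hardly at all. Going by the values given here, no measured step has a 3-amino-3-carboxypropyl group, so the direction is uncertain; a modest rise is expected, a number 9 percentage points higher from compound 3 to compound 4 (within the scatter), and compound 4 is estimated at 22%, between 0% and 50%.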

Compound 4, a percentage reported as inhibition, at one concentration (the size of the read-out at that concentration, not a potency): 5%
For compound 4 the middle estimate is 17 percentage points above the measured one; low and high end bracket the measured number.
By their numbers in this assay, from the lowest: compounds 4, 2 and 3 (each within the scatter of the next); then compound 1.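

In this assay, putting the open 3-amino-3-carboxypropyl chain in place of the 3-aminocyclohexyl ring gives a number 8 percentage points lower from compound 3 to compound 4 (within the scatter), so adding a carboxylic acid and opening the ring do not separate these two compounds. The comparison with the dimethylamino chain gives a number 3 percentage points lower from compound 2 to compound 4 (within the scatter), while the comparison with the methylamino chain gives a number 40 percentage points lower from compound 1 to compound 4 (beyond the scatter), so only compound 1 stands apart. No supporting data bear on this result. Still open, from the compounds shown here alone, is whether a methyl ester in place of the carboxylic acid, or a longer chain ending in a methylamino group, would change the number.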